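The source may hold more compounds than are shown below. What is called first, only, known or untested is meant among the compounds shown, and "the series" means these compounds.

Compound 3 `COc1ccc(-c2cc(C(C)=O)c3[nH]c(-c4ccccc4)cc3c2)cc1` was tested in a functional assay on HeLa cells (Homo sapiens) for cytotoxicity, read by MTT assay, with a stated time of 2 days, tested at 0.1 uM (on this read-out lower numbers stand for a stronger effect and higher numbers for a weaker effect at the one concentration tested), where compound 3 gives 87.9%. Among the three compounds measured so far it stands second highest: compound 2 `CC(=O)c1cc(-c2ccc(F)cc2)cc2cc(-c3ccccc3)[nH]c12` gives 90.3% in this assay, and compound 1 `CC(=O)c1cc(-c2ccccc2)cc2cc(-c3ccccc3)[nH]c12` gives 72.3%. The step of a number 2.4 percentage points lower from compound 2 to compound 3 (within the scatter) lies within the scatter, whereas a number 15.6 percentage points higher from compound 1 to compound 3 (beyond the scatter) lies beyond it. Compound 4 `COc1ccc(-c2cc(C(C)=O)c3[nH]c(-c4ccc(OC)cc4)cc3c2)cc1` has not yet been measured. It differs from compound 3 by methoxy in place of hydrogen on an aromatic carbon. Among the compounds with values here, two measured steps bear on this change, both of them a group entering on an aromatic carbon: a number 15.6 percentage points higher from compound 1 to compound 3 (beyond the scatter), the same kind of change, and a number 18 percentage points higher from compound 1 to compound 2 (beyond the scatter). Both raised the read-out, but compound 3 already stands near the top of what this assay can report, so the same change made a second time is expected to add little. For compound 4 a step of a number 4.1 percentage points higher from compound 3 to compound 4 (within the scatter) is therefore expected, within the scatter. The estimate for compound 4 in this assay is 92%, with a range from 80% to 100%.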

Compound 4, a percentage reported as activity, at one concentration (the size of the read-out at that concentration, not a potency): 74.5%
Compound 4: middle estimate off by 17.5 percentage points, on the high side; measured number outside the range, below it.
By their numbers in this assay, from the lowest: compounds 1 and 4 (each within the scatter of the next); then compounds 3 and 2 (each within the scatter of the next).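

In this assay, the step to methoxy on the second phenyl ring gave a number 13.4 percentage points lower from compound 3 to compound 4 (beyond the scatter) and thus a stronger effect, whereas the same kind of change on the first phenyl ring had gone the other way, with a number 15.6 percentage points higher from compound 1 to compound 3 (beyond the scatter). The earlier compounds had shown only rises when a group entered on an aromatic carbon, so this step shows that the direction of the phenyl to 4-methoxyphenyl change depends on where it is made in this series. No measurement available here accounts for this reversal.

Going by these compounds, it remains open whether the lower number depends on the methoxy already present on the first phenyl ring, or would also appear with that ring unsubstituted. Also open, on these data alone, is how an amine, a carboxylic acid or a longer chain such as butoxy would behave in place of this methoxy.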